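The compounds below may be only part of what the source reports. "The series", "measured", "known", "first", "only" and "open" are said of these compounds alone.

Measured in a functional assay on A549 cells (Homo sapiens) for cytotoxicity, read by MTT assay, with a stated time of 48 h; on this read-out higher numbers stand for weaker inhibition and lower numbers for stronger inhibition:

compound 1 `COc1ccc(-c2cn(C(C)=O)c(=O)n2-c2cc(OC)c(OC)c(OC)c2)cc1` gives 17800 nM
compound 2 `COc1ccc(-c2cn(C(C)=O)c(=O)n2-c2cc(OC)c(OC)c(OC)c2)cc1OC` gives > 50000 nM, a limit and not a number

As far as these compounds go, compound 2 stands at the limit of > 50000 nM in this assay, at which 1 of the 2 values shown sits, so its true position on the scale is unknown. Compound 3 `COc1ccc(-c2cn(C(C)=O)c(=O)n2-c2cc(OC)c(OC)c(OC)c2)cc1[N+](=O)[O-]`, not yet measured, keeps the rest of compound 2 but has nitro in place of methoxy on an aromatic carbon, ortho to a methoxy group: nitro in place of methoxy on an aromatic carbon.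

Among the compounds with values here, only one measured step bears on this change. It is an at least 2.8-fold higher number from compound 1 to compound 2 (0.44 log units; beyond the scatter), and it placed a methoxy on the very carbon that changes now. Within the data shown here, no measured compound carries a nitro, so that step gives only a weak guide. Compound 3 loses that methoxy, and compound 1 without it gives 17800 nM, so a move toward a lower number seems more likely than not. The expected change is modest, and it is written as an at least 1.7-fold lower number from compound 2 to compound 3 (0.25 log units; that floor lies within the scatter). The assay may well report only a limit again. For compound 3 the estimated value is 28000 nM, with an expected range from 9000 nM to 50000 nM.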

Compound 3, half-maximal inhibitory concentration: 40900 nM
Compound 3: middle estimate off by 1.5-fold (0.16 log units), on the low side, and the stated range covers the measured number.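

In this assay, putting nitro on this carbon in place of hydrogen gives a 2.3-fold higher number from compound 1 to compound 3 (0.36 log units; beyond the scatter), so this position is not indifferent to what it carries: among the three compounds shown, both methoxy and nitro go with a higher number than hydrogen, and no compound here goes against that. Exchanging methoxy for nitro on the same carbon gives an at least 1.2-fold lower number from compound 2 to compound 3 (0.08 log units; that floor lies within the scatter), which on its own does not establish a real difference between the two groups, since the floor of that step does not clear the usual scatter. Compound 2 gives only a limit, and the true size of its step to compound 3 stays unknown because of it: the limit of > 50000 nM in this assay, at which 1 of the 3 values shown sits.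

As far as these compounds go, what remains open is whether hydrogen is the best of all possible occupants of this carbon or just the best of these three, and whether nitro truly improves on methoxy. An amine, a fluorine atom or a carboxylic acid at this position would show whether any group can match or improve on compound 1, or whether every addition here goes with a higher number.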